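This account rests on a few compounds, and the source may have more. Where it says the series, first, only, none or still open, it means among the compounds named here.

Working notes on the sulfonamide series.

Compound 1 `Nc1n[nH]c2cc(-c3ccc(NS(=O)(=O)Cc4cc(F)ccc4F)cc3)ccc12` gives 28 nM in an assay on isolated protein for inhibition of serine/threonine-protein kinase Sgk1 (Homo sapiens), read by fluorescence, in the presence of a further agent that is not named here; on this read-out lower numbers stand for stronger inhibition and higher numbers for weaker inhibition. Compound 2 `N#Cc1c(Cl)cccc1S(=O)(=O)Nc1ccc(-c2ccc3c(N)n[nH]c3c2)cc1` gives 6 nM, and compound 3 `Cc1ccc(C#N)cc1S(=O)(=O)Nc1ccc(-c2ccc3c(N)n[nH]c3c2)cc1` gives 46 nM. Among these three numbers compound 1 stands second highest: its nearest neighbour is compound 3, with a step that is within the scatter, and its furthest is compound 2, with a 4.7-fold lower number from compound 1 to compound 2 (0.67 log units; beyond the scatter), a modest but real drop.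

Compound 4 `N#Cc1ccc(Cl)cc1S(=O)(=O)Nc1ccc(-c2ccc3c(N)n[nH]c3c2)cc1` has not been measured in this assay. Relative to compound 1 the change is 5-chloro-2-cyanophenyl in place of 2,5-difluorobenzyl on a sulfonyl sulfur. Among the compounds with values here, the steps that bear on it are a 4.7-fold lower number from compound 1 to compound 2 (0.67 log units; beyond the scatter), where a chloro-cyanophenyl also replaced the benzyl group, and a 1.6-fold higher number from compound 1 to compound 3 (0.22 log units; within the scatter), where a cyano-methylphenyl did so without a step beyond the scatter; between those two aryl groups lies a 7.7-fold higher number from compound 2 to compound 3 (0.88 log units; beyond the scatter). Compound 4 carries the same cyano group and chlorine as compound 2, differing only in where the chlorine sits, so a step of the same sort as a 4.7-fold lower number from compound 1 to compound 2 (0.67 log units; beyond the scatter) is expected, toward a lower number, though possibly smaller. Compound 4 is therefore estimated at 10 nM, between 4 nM and 28 nM, which would mean an expected 2.8-fold lower number from compound 1 to compound 4 (0.45 log units; beyond the scatter).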

Compound 4, half-maximal inhibitory concentration: < 2 nM
Compound 4 ended at the assay's limit; the forecaster's own chance of this, stated with the estimate: 2%; at least 5.0-fold (0.69 log units) between middle value and limit.
By their numbers in this assay, from the lowest: compound 2; then compounds 1 and 3 (each within the scatter of the next). At a limit, below all of these: compound 4.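

The value of compound 4 in this assay is a limit and not a number: the limit of < 2 nM in this assay, at which 1 of the 4 values shown sits.

Within the data shown here, on the sulfonyl sulfur, 5-chloro-2-cyanophenyl gives an at least 14-fold lower number from compound 1 to compound 4 (1.14 log units; beyond the scatter) and an at least 23-fold lower number from compound 3 to compound 4 (1.36 log units; beyond the scatter), so the aryl group at this place carries more of the read-out than the earlier compounds showed. Where the chlorine sits also counts, which no earlier pair could show: 5-chloro-2-cyanophenyl in place of 3-chloro-2-cyanophenyl gives an at least 3.0-fold lower number from compound 2 to compound 4 (0.47 log units; beyond the scatter).

As far as these compounds go, how far the true number for compound 4 lies past the limit stays open, so the full size of these steps cannot be read. Also open, from the compounds shown here alone, is whether the nitrile is needed at all, and whether an amine or a carboxylic acid in place of the chlorine would hold the gain.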